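Cytotoxicity of a cyanobenzyl analogue, before its measurement

This account rests on a few compounds, and the source may have more. Where it says the series, first, only, none or still open, it means among the compounds named here.

Compound 1 `C=CCN1C(=O)N(Cc2ccccc2)S(=O)(=O)n2cccc21`: in an ADME assay on MT4 cells (Homo sapiens) for cytotoxicity, read by MTT assay, with a stated time of 5 days (a higher number here means that more compound is tolerated, a lower number that less compound is tolerated), compound 1 gives > 802000 nM, a limit of the assay.
Compound 2 `O=C1N(C/C=C/c2ccccc2)c2cccn2S(=O)(=O)N1Cc1ccccc1`: in this assay compound 2 gives > 318000 nM, again a limit of the assay.

The step that the two limits leave unreadable from compound 1 to compound 2 cannot be sized because both the limit of > 318000 nM in this assay, at which 1 of the 2 values shown sits, and the limit of > 802000 nM in this assay, at which 1 of the 2 values shown sits, are limits rather than numbers. Within the data shown here, compound 2 therefore stands only at a limit, and the one further value shown is also a limit. Compound 3 `N#Cc1cccc(CN2C(=O)N(Cc3ccccc3)S(=O)(=O)n3cccc32)c1` differs from compound 2 by 3-cyanophenyl in place of 2-phenylethenyl on a saturated chain carbon bound to an amide-type nitrogen in a ring. Among the measured compounds shown here, the only measured step bearing on this position is the unreadable one from compound 1 to compound 2, so no sized step exists to carry over. With nothing beyond two limits to go on, compound 3 is expected to be tolerated in this assay in the same way, giving the estimate 320000 nM, with a range from 100000 nM to 1000000 nM. The step that the limit leaves unreadable from compound 2 to compound 3 that this estimate implies is expected to lie within the scatter.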

Compound 3, half-maximal cytotoxic concentration: > 318000 nM
Compound 3: only a limit was reported (the forecaster's own chance of this, stated with the estimate: 75%); the middle value does not contradict the limit.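

Neither the step from compound 2 to compound 3 nor the step from compound 1 to compound 3 can be read, as compound 3 gives only a limit: the limit of > 318000 nM in this assay, at which 2 of the 3 values shown sit.

The compounds shown leave open what concentration of any of compounds 1, 2 and 3 is no longer tolerated in this assay, and whether the groups at this place differ at all.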